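Exchanging naphthalen-1-yl for 3-(trifluoromethyl)phenyl on the shared core

A few compounds are considered here, and "the series" means these few. Any claim that something is new, unique, unknown or untested is made for them only; others in the source may bear on it.

Compound 1 `c1ccc2c(-c3cn4ccnc4c(-c4ccc5ncn(C6CCCCC6)c5c4)n3)cccc2c1` stands highest of the three numbers in a functional assay on HL-60 cells (Homo sapiens) for inhibition, read by sulforhodamine B assay, with a stated time of 48 h, tested at 10 uM (a lower number here means less inhibition, a higher number more inhibition at the concentration tested (going by the name of the read-out)), giving 38.9%. Compound 2 `c1cn2cc(-c3ccsc3)nc(-c3ccc4ncn(C5CCCCC5)c4c3)c2n1` gives 18.5% in this assay, and compound 3 `c1csc(-c2cn3ccnc3c(-c3ccc4ncn(C5CCCCC5)c4c3)n2)c1` gives 26.6%. Compound 4 `FC(F)(F)c1cccc(-c2cn3ccnc3c(-c3ccc4ncn(C5CCCCC5)c4c3)n2)c1` carries the change (3-(trifluoromethyl)phenyl in place of naphthalen-1-yl on an aromatic carbon). Among the compounds with values here, two measured steps bear on it, both exchanging naphthalen-1-yl for a single aromatic ring: a number 20.4 percentage points lower from compound 1 to compound 2 (beyond the scatter) and a number 12.3 percentage points lower from compound 1 to compound 3 (beyond the scatter). The step of a number 8.1 percentage points higher from compound 2 to compound 3 (within the scatter) adds little. A modest fall in this assay is therefore expected, possibly smaller than for the thiophenes since one six-membered ring of carbon is kept, estimated as a number 8.9 percentage points lower from compound 1 to compound 4 (within the scatter). Compound 4 is estimated at 30% in this assay, with a range from 15% to 45%.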

Compound 4, a percentage reported as inhibition, at one concentration (the size of the read-out at that concentration, not a potency): 1.06%
Beside the measured number, compound 4's estimate is 28.9 percentage points above it; the whole stated range lies above it.
By their numbers in this assay, from the lowest: compound 4; then compounds 2 and 3 (each within the scatter of the next); then compound 1.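

In this assay, within the data shown here, the exchange of naphthalen-1-yl for 3-(trifluoromethyl)phenyl gives a number 37.8 percentage points lower from compound 1 to compound 4 (beyond the scatter), the only large step at this position so far. The same group also stands under both thiophenes, with a number 25.5 percentage points lower from compound 3 to compound 4 (beyond the scatter) and a number 17.4 percentage points lower from compound 2 to compound 4 (beyond the scatter), so keeping one six-membered aromatic ring of carbon does not by itself hold up the number here. No measurement at hand accounts for the fall.

Open, on these data alone, is whether the fall follows the trifluoromethyl group or the loss of the second ring. A plain phenyl, or an amine in place of trifluoromethyl, would separate the two.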